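From 4-fluorobenzyl to 4-methoxybenzyl: working notes on the series

A few compounds are considered here, and "the series" means these few. Any claim that something is new, unique, unknown or untested is made for them only; others in the source may bear on it.

Measured in a functional assay on MDA-MB-435 cells (Homo sapiens) for cytotoxicity, read by MTT assay, with a stated time of 72 h; a higher number here means a weaker inhibitor, a lower number a stronger inhibitor:
- compound 1 `COc1cccc(CNC(=O)c2nc(Br)c3cccnc3c2N[C@H]2CC[C@H](N)CC2)c1` gives 7000 nM
- compound 2 `N[C@H]1CC[C@H](Nc2c(C(=O)NCc3ccc(F)cc3)nc(Br)c3cccnc23)CC1` gives 6000 nM

Compound 2 at 6000 nM stands within the scatter of compound 1 at 7000 nM, so the two values cannot be ranked. Compound 3 `COc1ccc(CNC(=O)c2nc(Br)c3cccnc3c2N[C@H]2CC[C@H](N)CC2)cc1` has not yet been measured. Its difference from compound 2 is methoxy in place of fluoro on an aromatic carbon, which is methoxy in place of fluoro on an aromatic carbon, para to a large group. The same difference reads 4-fluorophenyl to 4-methoxyphenyl.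

Within the data shown here, only one measured step bears on this change: a 1.2-fold lower number from compound 1 to compound 2 (0.07 log units; within the scatter). It exchanges 3-methoxyphenyl for 4-fluorophenyl, whereas compound 3 carries 4-methoxyphenyl, so it is related evidence and not the same change. Among the measured compounds shown here, no measured pair isolates the 4-methoxyphenyl group. In this assay no shift beyond the scatter is therefore expected, and the estimated step is a 1.1-fold higher number from compound 2 to compound 3 (0.03 log units; within the scatter). For compound 3 the expected value is 6500 nM, with an estimated range from 3500 nM to 12000 nM.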

Compound 3, half-maximal inhibitory concentration: 5000 nM
The estimate for compound 3 lay 1.3-fold (0.11 log units) above the measured number, within the range that was stated.
By their numbers in this assay, from the lowest: compounds 3, 2 and 1 (each within the scatter of the next).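

In this assay, methoxy in place of fluoro on an aromatic carbon, para to a large group, gives a 1.2-fold lower number from compound 2 to compound 3 (0.08 log units; within the scatter). This position therefore accepts 2 heavy atoms and a hydrogen-bond acceptor in place of a single fluorine without a change that can be read, a direct comparison that the earlier pair, which differed in both the substituent and its place, could not give. The second new comparison, 4-methoxyphenyl in place of 3-methoxyphenyl, gives a 1.4-fold lower number from compound 1 to compound 3 (0.15 log units; within the scatter), so the location of the methoxy group on this ring also produces no readable separation, and no measurement available for these compounds bears on the result.

The three compounds show only that fluoro and methoxy at these places cannot be told apart here, and they leave open whether an amine, a hydroxyl or a carboxylic acid on the same aromatic carbon would move the value beyond the scatter. Also open, from the compounds shown here alone, is whether a longer chain in place of the benzyl link would do so, as all three compounds keep that link and the rest of the shared core unchanged.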